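Replacing the Aromatic Group: From Compound 2 to Compound 3

A few compounds are considered here, and "the series" means these few. Any claim that something is new, unique, unknown or untested is made for them only; others in the source may bear on it.

Among the compounds with values here, in a functional assay on DU-145 cells (Homo sapiens) for cytotoxicity, read by sulforhodamine B assay, with a stated time of 48 h (on this read-out higher numbers stand for weaker inhibition and lower numbers for stronger inhibition), compound 2 `Cc1ccccc1C1=NO[C@]2(C1)C(=O)O[C@@H]1[C@H]2CC[C@H](C)[C@]2(O)C=CC(=O)[C@@]12C` gives 12000 nM, the lower of the two numbers so far, while compound 1 `C[C@H]1CC[C@@H]2[C@@H](OC(=O)[C@]23CC(c2ccccc2[N+](=O)[O-])=NO3)[C@]2(C)C(=O)C=C[C@@]12O` gives 34000 nM. Compound 3 `C[C@H]1CC[C@@H]2[C@@H](OC(=O)[C@]23CC(c2ccc(C#N)cc2)=NO3)[C@]2(C)C(=O)C=C[C@@]12O` is still unmeasured: 4-cyanophenyl replaces 2-methylphenyl on a carbon with a double bond to nitrogen (4-cyanophenyl in place of 2-methylphenyl on a carbon with a double bond to nitrogen). Within the data shown here, the only guide is a modest measured step that put methyl in place of nitro on an aromatic carbon, a 2.8-fold lower number from compound 1 to compound 2 (0.45 log units; beyond the scatter). A similarly small move toward a higher number is therefore expected in this assay, with an estimated step of a 1.7-fold higher number from compound 2 to compound 3 (0.22 log units; within the scatter). For compound 3 the estimated value is 20000 nM, with an expected range of 7000 nM to 50000 nM.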

Compound 3, half-maximal inhibitory concentration: 26000 nM
Beside the measured number, compound 3's estimate is 1.3-fold (0.11 log units) below it; low and high end bracket the measured number.
By their numbers in this assay, from the lowest: compound 2; then compounds 3 and 1 (each within the scatter of the next).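

At this ring carbon, 4-cyanophenyl in place of 2-methylphenyl gives a modest loss in this assay, with a 2.2-fold higher number from compound 2 to compound 3 (0.34 log units; beyond the scatter). Against 2-nitrophenyl, the same group makes no difference that can be told apart, with a 1.3-fold lower number from compound 1 to compound 3 (0.12 log units; within the scatter), so of these three groups only 2-methylphenyl stands apart, at the lower number. Nothing available explains this result.

Because compound 3 changes both the group and its place on the phenyl ring, the effects of the two cannot be separated here. The compounds shown leave open how 4-methylphenyl, 2-cyanophenyl or a phenyl ring carrying an amine would compare.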